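Swapping Trifluoromethyl for Fluoro in a Cytotoxic Series

A few compounds are considered here, and "the series" means these few. Any claim that something is new, unique, unknown or untested is made for them only; others in the source may bear on it.

Three compounds have been measured in a functional assay on QGY-7703 cells (Homo sapiens) for cytotoxicity, read by MTT assay, with a stated time of 24 h; a higher number here means a weaker inhibitor, a lower number a stronger inhibitor:

compound 1, `O=C1/C(=C/c2cccnc2)CNC/C1=C\c1ccccc1F`, gives 8890 nM
compound 2, `O=C1/C(=C/c2cccnc2)CNC/C1=C\c1ccccc1C(F)(F)F`, gives 3800 nM
compound 3, `O=C1/C(=C/c2ccncc2)CN(S(=O)(=O)c2ccc(C(F)(F)F)cc2)C/C1=C\c1ccccc1C(F)(F)F`, gives 4680 nM

The change fluoro in place of trifluoromethyl on an aromatic carbon produced a 2.3-fold higher number from compound 2 to compound 1 (0.37 log units; beyond the scatter) in this assay. Compound 3 has a different core; the difference between the cores of compound 3 and compound 2 is not broken down here, and their values lie within the scatter of each other. Compound 4, `O=C1/C(=C/c2ccncc2)CN(S(=O)(=O)c2ccc(F)cc2)C/C1=C\c1ccccc1C(F)(F)F`, differs from compound 3 by fluoro in place of trifluoromethyl on an aromatic carbon. This is the same kind of change as before, not the same: the earlier one sat ortho to a large group, this one para to a large group. A step of similar size is expected, a 1.8-fold higher number from compound 3 to compound 4 (0.26 log units; within the scatter), resting on a 2.3-fold higher number from compound 2 to compound 1 (0.37 log units; beyond the scatter). Compound 4 is thus estimated at 8500 nM, between 4000 nM and 17000 nM.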

Compound 4, half-maximal inhibitory concentration: 7700 nM
Estimate against measurement, compound 4: 1.1-fold (0.04 log units) above; the range from low to high includes it.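

In this assay, putting fluoro in place of trifluoromethyl on the sulfonyl-bearing aromatic ring gave a 1.6-fold higher number from compound 3 to compound 4 (0.22 log units; within the scatter). Set beside the earlier case, the two steps cannot be told apart: the same change on two cores in this assay, a 2.3-fold higher number (0.37 log units; beyond the scatter) from compound 2 to compound 1 and a 1.6-fold higher number (0.22 log units; within the scatter) from compound 3 to compound 4, 1.4-fold (0.15 log units) apart, within the scatter of two such steps. This fits the change carrying over from one core to the other, but the new step is on its own within the scatter, so it does not show that the change has a real effect on the core of compound 3, and two pairs make no rule for the series.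

Still open, on these data alone, is whether another group in that place, such as a methoxy group or an amine, would give a number clearly apart from those of compound 3 and compound 4. Also open, as far as these compounds go, is how the change behaves on any further core.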